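A cyclopentyl swap on compound 2

This account rests on a few compounds, and the source may have more. Where it says the series, first, only, none or still open, it means among the compounds named here.

Measured in a functional assay on K562 cells (Homo sapiens) for antiproliferative activity, read by MTT assay, with a stated time of 48 h; on this read-out higher numbers stand for weaker inhibition of growth and lower numbers for stronger inhibition of growth:
Compound 1 `COc1ccccc1OCCNc1cnn(Cc2ccc(OC)c(OCC3CC3)c2)c(=O)c1Cl`: > 100000 nM, a limit of the assay
Compound 2 `COc1ccccc1OCCNc1cnn(Cc2ccc(OC(F)F)c(OCC3CC3)c2)c(=O)c1Cl`: 67600 nM

For the measured compounds named here, compound 2, at 67600 nM, holds the only actual number so far. Compound 3 `COc1ccccc1OCCNc1cnn(Cc2ccc(OC(F)F)c(OC3CCCC3)c2)c(=O)c1Cl` differs from it by cyclopentyl in place of cyclopropylmethyl on an oxygen on an aromatic ring, with cyclopentyl in place of cyclopropylmethyl on an oxygen on an aromatic ring. Going by the values given here, the one measured step, an at least 1.4-fold lower number from compound 1 to compound 2 (0.17 log units; that floor lies within the scatter), concerns a different group and gives no size for this change. No shift beyond the scatter is therefore expected in this assay. The expected step is a 1.4-fold lower number from compound 2 to compound 3 (0.13 log units; within the scatter). For compound 3 the estimate is 50000 nM, with an expected range of 18000 nM to 100000 nM.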

Compound 3, concentration for 50% growth inhibition: > 100000 nM
Compound 3 gave a limit, no number; the forecaster's own chance of this, stated with the estimate: 25%; middle value at least 2.0-fold (0.30 log units) away from the limit.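

In this assay compound 3 gives > 100000 nM, which is a limit and not a number. Cyclopentyl in place of cyclopropylmethyl gives an at least 1.4-fold higher number from compound 2 to compound 3 (0.17 log units; that floor lies within the scatter), so this change on the oxygen shows no gain in growth inhibition, while its true size stays unknown. Unlike the earlier step, this one tests the second oxygen substituent, and the limit now describes most of the set: the limit of > 100000 nM in this assay, at which 2 of the 3 values shown sit.

As far as these compounds go, whether a longer chain or an amine on this oxygen would give a value clear of that limit remains open.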